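Chloro Placement on a Shared Core: Notes for Compound 3

The source may report more compounds than this note shows. Statements on the series, on what has been measured and on what is new or still open speak of the compounds shown alone.

Measured compounds:
Compound 1, `C/C(=N\OCC(=O)O)c1ccccc1`: in a functional assay on the whole organism for inhibition, with Rattus norvegicus as the target, read by paw edema, with stated times of 1 h and 3 h, at a dose of 50 mg/kg by the oral route (a lower number here means less inhibition, a higher number more inhibition at the dose given (going by the name of the read-out)), compound 1 gives < 20%, which is a limit of the assay and not a number.
Compound 2, `C/C(=N\OCC(=O)O)c1ccccc1Cl`: in this assay compound 2 gives < 20%, also a limit of the assay.

In this assay, among the measured compounds shown here, compound 1 stands only at a limit, and the one further value shown is a limit as well, so no number for compound 1 is known. For the measured compounds named here, the sole measured step, a step that the two limits leave unreadable from compound 1 to compound 2, cannot be read in size since both of its ends sit at the limit of < 20% in this assay, at which 2 of the 2 values shown sit. Compound 3, `C/C(=N\OCC(=O)O)c1cccc(Cl)c1`, is not yet measured; it differs from compound 1 by chloro in place of hydrogen on an aromatic carbon. The step from compound 1 to compound 2 bears on this change, bringing in the same group on the same kind of carbon, but its size is not readable. No rise beyond the scatter is therefore expected, and the expected step is a step that the limit leaves unreadable from compound 1 to compound 3. Compound 3 is expected to give about 10%, between 0% and 22%, most likely again as a limit of the assay.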

Compound 3, a percentage reported as inhibition, in the whole organism at one dose (the size of the read-out at that dose, not a potency): 20%
For compound 3 the middle estimate is 10 percentage points below the measured one; the measured number falls inside the stated range.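

Among the compounds shown here, with chloro in place of hydrogen on an aromatic carbon, meta to a group of 8 heavy atoms, the core now gives a number and not a limit: in this assay compound 3 gives 20%, the only number among the values shown. As far as these compounds go, the change reads as a number no lower from compound 1 to compound 3 (the limit leaves the size open), so its direction is bounded but its size stays open. The other values remain at a single limit of the assay: the limit of < 20% in this assay, at which 2 of the 3 values shown sit.

From the compounds shown here alone, whether a methoxy group or an amine on that same aromatic carbon would give a number clearly higher than that of compound 3 remains open. The compounds shown also leave open whether a second chloro on the ring would add to the read-out of compound 3 or leave it unchanged.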